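The source may hold more compounds than are shown below. What is called first, only, known or untested is meant among the compounds shown, and "the series" means these compounds.

Compound 1, `Cc1noc(C)c1-c1ccc2c(c1)C(c1ccccc1)N(Cc1nnc(-c3ccccc3)o1)C(=O)N2C`: 26.7%
Compound 2, `Cc1noc(C)c1-c1ccc2c(c1)C(c1ccccc1)N(Cc1ncc(-c3ccccc3)o1)C(=O)N2C`: 15.1%
Compound 3, `Cc1noc(C)c1-c1ccc2c(c1)C(c1ccccc1)N(Cc1nc(-c3ccc(F)cc3)cs1)C(=O)N2C`: 12.6%

In a functional assay on U-266 cells (Homo sapiens) for inhibition, read by MTT assay, with a stated time of 48 h, tested at 0.1 uM (a higher number here means more inhibition at the concentration tested (going by the name of the read-out), a lower number less inhibition), compound 3 stands lowest of the three numbers: a number 2.5 percentage points lower from compound 2 to compound 3 (within the scatter), and a number 14.1 percentage points lower from compound 1 to compound 3 (beyond the scatter). Compound 4, `Cc1noc(C)c1-c1ccc2c(c1)C(c1ccccc1)N(Cc1nnc(-c3ccc(F)cc3)o1)C(=O)N2C`, differs from compound 3 by 5-(4-fluorophenyl)-1,3,4-oxadiazol-2-yl in place of 4-(4-fluorophenyl)-1,3-thiazol-2-yl on a saturated chain carbon bound to an amide-type nitrogen in a ring. The step that bears most directly on this change is a number 14.1 percentage points lower from compound 1 to compound 3 (beyond the scatter), which runs in nearly the opposite direction, the fluorine on the phenyl being the only part retained; the step of a number 11.6 percentage points lower from compound 1 to compound 2 (beyond the scatter) likewise shows the phenyl-oxadiazolyl variant standing higher than another five-membered ring. Returning to the oxadiazole in compound 4 is therefore expected to raise the number beyond the scatter, a number 12.4 percentage points higher from compound 3 to compound 4 (beyond the scatter). Compound 4 is estimated at 25%, within a range of 13% to 37%.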

Compound 4, a percentage reported as inhibition, at one concentration (the size of the read-out at that concentration, not a potency): 26.8%
Estimate against measurement, compound 4: 1.8 percentage points below, within the range that was stated.
By their numbers in this assay, from the lowest: compounds 3 and 2 (each within the scatter of the next); then compounds 1 and 4 (each within the scatter of the next).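

In this assay, fluoro in place of hydrogen on an aromatic carbon leaves the oxadiazole series unchanged (a number 0.1 percentage points higher from compound 1 to compound 4 (within the scatter)), while with the 4-fluorophenyl held fixed, the 1,3,4-oxadiazol-2-yl stands clear of the 1,3-thiazol-2-yl (a number 14.2 percentage points higher from compound 3 to compound 4 (beyond the scatter)). It also stands clear of the 5-phenyl-1,3-oxazol-2-yl (a number 11.7 percentage points higher from compound 2 to compound 4 (beyond the scatter)), so the heteroaromatic ring at this position matters more here than the fluoro. Nothing measured here explains this difference between the rings.

Open, going by these compounds, is whether an amine in place of the fluoro would keep the oxadiazole's standing. Also open, on these data alone, is whether a longer chain on the amide-type nitrogen in a ring would keep it.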